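A few compounds are considered here, and "the series" means these few. Any claim that something is new, unique, unknown or untested is made for them only; others in the source may bear on it.

Measured so far:

compound 1, `N#Cc1ccc(NC(=O)c2ccc(F)cc2O)cc1`, in a functional assay on KG-1 cells (Homo sapiens) for cytotoxicity, read by luminescence and CellTiter-Glo, with a stated time of 3 days (a lower number here means a stronger inhibitor, a higher number a weaker inhibitor), gives 3150 nM
compound 2, `O=C(Nc1ccc(Br)c(Cl)c1)c1cc(F)ccc1O`, in this assay gives 670 nM

Two compounds carry numbers, and compound 1 stands at the higher of them; compound 2 sits at a lower number, and the gap between the two lies beyond the usual scatter. The two differ in more than one place, so nothing is read from that gap beyond what the two values show.

The step now followed goes from compound 1 to compound 3, `N#Cc1ccc(NC(=O)c2ccc(-c3cccnc3)cc2O)cc1`. The change is pyridin-3-yl in place of fluoro on an aromatic carbon. The fluoro leaves from the aromatic carbon meta to the hydroxy group and para to the large group; the pyridin-3-yl enters there, bringing one six-membered aromatic ring with one hetero atom and one hydrogen-bond acceptor.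

Within the data shown here, no measured pair in this set shows such an exchange, so the size of the step is open. The expectation is a moderate move toward a lower number in this assay, of a size that may or may not clear the scatter, with a wide range to either side.

For compound 3 the estimate in this assay is 1500 nM, between 400 nM and 6000 nM. This estimate corresponds to an expected step of a 2.1-fold lower number from compound 1 to compound 3 (0.32 log units; beyond the scatter).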

Compound 3, half-maximal inhibitory concentration: 7940 nM
Estimate against measurement, compound 3: 5.3-fold (0.72 log units) below; the measured number lies above the stated range.
By their numbers in this assay, from the lowest: compound 2; then compound 1; then compound 3.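

Among these compounds, at the aromatic carbon meta to the hydroxy group and para to the large group, pyridin-3-yl in place of fluoro gives, in this assay, a 2.5-fold higher number from compound 1 to compound 3 (0.40 log units; beyond the scatter), the first one-place step. The exchange moves the number toward the weaker side, yet the change is modest for a group that brings a whole six-membered aromatic ring and a hydrogen-bond acceptor: compound 3 still reads 7940 nM, so activity at this position does not depend strictly on keeping fluoro. Nothing measured here bears on what lies behind this rise.

As far as these compounds go, whether the step belongs to the ring nitrogen or to the ring as a whole stays open, and a phenyl group at the same carbon would separate the two. Also open, from the compounds shown here alone, is whether a smaller replacement for fluoro at this carbon, such as a methoxy group or a small amine, would hold the number near that of compound 1 or take it lower.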